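The compounds below may be only part of what the source reports. "The series", "measured", "known", "first", "only" and "open" are said of these compounds alone.

The series rests on the shared core of compound 1, `Cc1ccc(S(=O)(=O)NC(=O)Nc2ccccc2C(=O)/C=C/c2ccc(N(C)C)cc2)cc1`, in which a 4-(dimethylamino)phenyl group sits on a double-bonded chain carbon bound to a double-bonded chain carbon. In an ADME assay on the whole organism for cytotoxicity, with Artemia salina as the target, with a stated time of 24 h (on this read-out lower numbers stand for an effect already at smaller amounts and higher numbers for an effect only at larger amounts of compound), compound 1 gives 38.1 ug/mL. Compound 2, `COc1ccc(/C=C/C(=O)c2ccccc2NC(=O)NS(=O)(=O)c2ccc(C)cc2)cc1OC`, gives 12.9 ug/mL, and compound 3, `COc1cc(/C=C/C(=O)c2ccccc2NC(=O)NS(=O)(=O)c2ccc(C)cc2)ccc1O`, gives 17.8 ug/mL. Compound 3 thus stands second highest of the three numbers: its nearest neighbour is compound 2, with a 1.4-fold higher number from compound 2 to compound 3 (0.14 log units; within the scatter), and its furthest is compound 1, with a 2.1-fold lower number from compound 1 to compound 3 (0.33 log units; beyond the scatter).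

The step now followed leads from compound 3 to compound 4, `Cc1ccc(S(=O)(=O)NC(=O)Nc2ccccc2C(=O)/C=C/C=C/c2ccccc2)cc1`. The change is 2-phenylethenyl in place of 4-hydroxy-3-methoxyphenyl on a double-bonded chain carbon bound to a double-bonded chain carbon. For the measured compounds named here, two measured steps bear on this place: a 3.0-fold lower number from compound 1 to compound 2 (0.47 log units; beyond the scatter) and a 2.1-fold lower number from compound 1 to compound 3 (0.33 log units; beyond the scatter), both modest and both beyond the scatter, while a 1.4-fold higher number from compound 2 to compound 3 (0.14 log units; within the scatter) stays within the scatter. None of them, however, removes every hydrogen-bond donor and acceptor from the entering group or extends the chain as compound 4 does. With only the spread of the three measured numbers as a guide, the step to compound 4 is expected to be small, at most modest, with a somewhat higher number thought slightly more likely than a lower one, which is expressed as a 1.3-fold higher number from compound 3 to compound 4 (0.13 log units; within the scatter). For compound 4 the estimate is 24 ug/mL, with a range from 10 ug/mL to 60 ug/mL.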

Compound 4, concentration for half-maximal effect: 18.2 ug/mL
Compound 4: the middle estimate sits 1.3-fold (0.12 log units) above what was measured, and the stated range covers the measured number.
By their numbers in this assay, from the lowest: compounds 2, 3 and 4 (each within the scatter of the next); then compound 1.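

In this assay the change shows that this place tolerates the loss of both oxygen-bearing substituents and the addition of a double bond outside the aromatic ring, since the record gives a 1.0-fold higher number from compound 3 to compound 4 (0.01 log units; within the scatter) and also a 1.4-fold higher number from compound 2 to compound 4 (0.15 log units; within the scatter) with compounds 2, 3 and 4 all lying within the scatter of one another. The 2-phenylethenyl group has 0 hydrogen-bond donors and 0 hydrogen-bond acceptors, so neither count is needed at this place to match compound 2 and compound 3, and the 4-(dimethylamino)phenyl group of compound 1 is now the only one of the four that stands apart, as seen in a 2.1-fold lower number from compound 1 to compound 4 (0.32 log units; beyond the scatter) and in its steps to compound 2 and compound 3. Nothing at hand explains why these groups give such similar numbers.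

The compounds shown leave open whether the added double bond or the bare phenyl ring accounts for the result, which a plain phenyl group at this place would help to separate. They also leave open whether a primary amine or a carboxylic acid on the ring, or a longer chain such as 6-phenylhexa-1,3,5-trien-1-yl, would stay with compounds 2, 3 and 4 or move towards compound 1.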